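Benzyl ethers: 4-bromophenyl to 2-methylphenyl

A few compounds are considered here, and "the series" means these few. Any claim that something is new, unique, unknown or untested is made for them only; others in the source may bear on it.

Going by the values given here, in a functional assay on U-251 cells (Homo sapiens) for antiproliferative activity, read by MTT assay, with a stated time of 24 h (a higher number here means a weaker inhibitor, a lower number a stronger inhibitor), compound 1 `COc1cc(OC)c(-c2coc3cc(OCc4ccccc4)ccc3c2=O)cc1OC` gives 6750 nM and compound 2 `COc1cc(OC)c(-c2coc3cc(OCc4ccc(Br)cc4)ccc3c2=O)cc1OC` gives 10000 nM, so compound 2 stands within the scatter of the only other number available. Compound 3 `COc1cc(OC)c(-c2coc3cc(OCc4ccccc4C)ccc3c2=O)cc1OC` differs from compound 2 by 2-methylphenyl in place of 4-bromophenyl on a saturated chain carbon bound to an oxygen on an aromatic ring. Among the compounds with values here, the one measured step bearing on this, a 1.5-fold higher number from compound 1 to compound 2 (0.17 log units; within the scatter), is bromo in place of hydrogen on an aromatic carbon and lies within the scatter. Within the data shown here, no measured step covers a 2-methylphenyl group, so no change beyond the scatter is foreseen. The expected step is a 1.3-fold lower number from compound 2 to compound 3 (0.10 log units; within the scatter), within the scatter. Compound 3 is estimated at 8000 nM, with an expected range of 4000 nM to 16000 nM.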

Compound 3, half-maximal inhibitory concentration: 2000 nM
Estimate against measurement, compound 3: 4.0-fold (0.60 log units) above, outside the stated range (below it).
By their numbers in this assay, from the lowest: compound 3; then compounds 1 and 2 (each within the scatter of the next).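

Substitution on the benzyl ring of the ether can move the number in this assay beyond the scatter, which the bromo step a 1.5-fold higher number from compound 1 to compound 2 (0.17 log units; within the scatter) did not show. The 2-methylphenyl group gives a 5.0-fold lower number from compound 2 to compound 3 (0.70 log units; beyond the scatter) against 4-bromophenyl, and the same group gives a 3.4-fold lower number from compound 1 to compound 3 (0.53 log units; beyond the scatter) against the unsubstituted benzyl ether. No measured evidence accounts for these steps.

Going by these compounds, it remains open whether the change follows the methyl group or its place on the ring, which 4-methylphenyl and 2-bromophenyl would separate. On these data alone, how an amine or a carboxylic acid on this ring would read also remains open.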